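From furan-2-yl to 3-cyanophenyl on the carbonyl carbon

The source may report more compounds than this note shows. Statements on the series, on what has been measured and on what is new or still open speak of the compounds shown alone.

Compound 1 `COc1ccc(-c2cnc(NC(=O)c3ncc[nH]3)n2C)cc1` gives > 100000 nM as a limit
Compound 2 `COc1ccc(-c2cnc(NC(=O)C3CCNCC3)n2C)cc1` gives > 100000 nM as a limit
Compound 3 `COc1ccc(-c2cnc(NC(=O)c3ccco3)n2C)cc1` gives > 100000 nM as a limit

In a toxicity assay on THP-1 cells (Homo sapiens) for inhibition (on this read-out higher numbers stand for lower toxicity in this test and lower numbers for higher toxicity in this test), compound 3 gives > 100000 nM and this is a limit, not a number. All three compounds share the limit of > 100000 nM in this assay, at which 3 of the 3 values shown sit, and no gap can be read among them. Compound 4 `COc1ccc(-c2cnc(NC(=O)c3cccc(C#N)c3)n2C)cc1` carries 3-cyanophenyl in place of furan-2-yl on a carbonyl carbon. The measured changes at that same place are a step that the two limits leave unreadable from compound 1 to compound 3 and a step that the two limits leave unreadable from compound 2 to compound 3 and also a step that the two limits leave unreadable from compound 1 to compound 2 and none of them gives a size to carry over. No step beyond the scatter is therefore expected in this assay for this swap. Expected here is a number no higher from compound 3 to compound 4 (the limit leaves the size open) and no more. For compound 4 the estimated value is 100000 nM with an expected range from 40000 nM to 200000 nM and the assay may well report only a limit again.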

Compound 4, half-maximal cytotoxic concentration: > 100000 nM
Compound 4: no number, only a limit (the forecaster's own chance of this, stated with the estimate: 85%); the middle value lies on the limit itself.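

Compound 4 also gives only a limit, so no step can be read between it and compound 1, compound 2 or compound 3 in this assay: the limit of > 100000 nM in this assay, at which 4 of the 4 values shown sit. On these data alone, whether these groups on the carbonyl carbon differ at all in this assay stays open.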